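One rearranged side chain, from compound 1 to compound 4

The source may hold more compounds than are shown below. What is called first, only, known or untested is meant among the compounds shown, and "the series" means these compounds.

Measured in a physicochemical assay for solubility, in phosphate buffer, measured as thermodynamic solubility, at pH 7.4; a higher number here means a more soluble compound, a lower number a less soluble compound:
Compound 1 `CS(=O)(=O)NC(=O)CCc1cn(-c2ccc(Br)cc2)nc1-c1ccc(Cl)cc1` gives 170000 nM
Compound 2 `CS(=O)(=O)NC(=O)CCc1cn(-c2ccncc2)nc1-c1ccc(Cl)cc1` gives 190000 nM
Compound 3 `CS(=O)(=O)NC(=O)CCc1cn(-c2ccc(Br)cc2)nc1-c1cnccn1` gives 196000 nM

Compound 1 stands with compound 2 and compound 3, all three within the scatter of each other. Compound 4 `CC(=O)NS(=O)(=O)CCc1cn(-c2ccc(Br)cc2)nc1-c1ccc(Cl)cc1` has the same atoms as compound 1, joined differently (acetylsulfamoyl in place of (methylsulfonyl)carbamoyl on a saturated chain carbon, two bonds along the chain from an aromatic carbon) on the saturated chain. Neither measured step touches this chain: a 1.1-fold higher number from compound 1 to compound 2 (0.05 log units; within the scatter) and a 1.2-fold higher number from compound 1 to compound 3 (0.06 log units; within the scatter) each change a group on an aromatic atom, and both lie within the scatter. The data therefore offer only indirect guidance. The estimated step is a 1.1-fold lower number from compound 1 to compound 4 (0.03 log units; within the scatter) with nothing beyond the scatter expected in this assay from this change. For compound 4 the expected value is 160000 nM (estimated range 70000 nM to 210000 nM).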

Compound 4, solubility: 165000 nM
For compound 4 the middle estimate is 1.0-fold (0.01 log units) below the measured one; the range from low to high includes it.
By their numbers in this assay, from the lowest: compounds 4, 1, 2 and 3 (each within the scatter of the next).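

In this assay, acetylsulfamoyl in place of (methylsulfonyl)carbamoyl gives a 1.0-fold lower number from compound 1 to compound 4 (0.01 log units; within the scatter), so the saturated chain, which compound 2 and compound 3 left untouched, now has a measured step of its own, and that step lies within the scatter. Joining the same atoms differently at this place therefore gives no step beyond the scatter in this pair. Nothing available bears on why the two arrangements read alike.

The compounds shown leave open whether a carboxylic acid or a longer chain at this place would give a step beyond the scatter.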